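The source may report more compounds than this note shows. Statements on the series, on what has been measured and on what is new or still open speak of the compounds shown alone.

Measured in a functional assay on HCT-116 cells (Homo sapiens) for inhibition, read by sulforhodamine B assay, with a stated time of 48 h, tested at 50 uM; on this read-out higher numbers stand for more inhibition of growth at the one concentration tested and lower numbers for less inhibition of growth:
Compound 1 `COc1ccc([C@@H]2C/C(=N/OCc3cn(-c4ccc(O)cc4)nn3)c3cc(CC=C(C)C)c(OC)cc3O2)cc1`: 65%
Compound 2 `COc1ccc([C@@H]2C/C(=N/OCc3cn(-c4ccccc4CO)nn3)c3cc(CC=C(C)C)c(OC)cc3O2)cc1`: 100%

Compound 2 holds the higher of these two numbers. Compound 3 `COc1ccc([C@@H]2C/C(=N/OCc3cn(-c4ccc(C(N)=O)cc4)nn3)c3cc(CC=C(C)C)c(OC)cc3O2)cc1` differs from it in one place: 4-carbamoylphenyl in place of 2-(hydroxymethyl)phenyl on an aromatic nitrogen. Among the compounds with values here, the only measured step, a number 35 percentage points higher from compound 1 to compound 2 (beyond the scatter), came with 2-(hydroxymethyl)phenyl in place of 4-hydroxyphenyl on an aromatic nitrogen. The 4-carbamoylphenyl of compound 3 resembles the 4-hydroxyphenyl of compound 1, which gives 65%, so a large fall is expected in this assay. The expected step is a number 35 percentage points lower from compound 2 to compound 3 (beyond the scatter). The estimate for compound 3 is 65%, with an expected range from 40% to 90%.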

Compound 3, percent growth inhibition at one concentration: 100%
The estimate for compound 3 lay 35 percentage points below the measured number; measured number outside the range, above it.
By their numbers in this assay, from the lowest: compound 1; then compounds 2 and 3 (each within the scatter of the next).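

In this assay, within the data shown here, there is no change at the digits printed from compound 2 to compound 3 (within the scatter), so 2-(hydroxymethyl)phenyl is not the only group on this aromatic nitrogen that gives the top number seen here. Carbamoyl in place of hydroxy on the aromatic carbon gives a number 35 percentage points higher from compound 1 to compound 3 (beyond the scatter), which shows that this single change on the phenyl ring separates a middling number from the top one. Nothing available explains these results.

On these data alone, whether a carboxylic acid or an amine in place of the carbamoyl would keep the number high remains open. With a single concentration, it is also unknown whether compound 2 and compound 3 would separate at lower doses.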